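The source may report more compounds than this note shows. Statements on the series, on what has been measured and on what is new or still open speak of the compounds shown alone.

Measured so far:
compound 1 `ClCc1ccc(Cn2cnc3c(Cl)ncnc32)cc1`: 9340 nM
compound 2 `ClCc1ccccc1Cn1cnc2c(Cl)nc(Cl)nc21`: 1540 nM

Both compounds were read in a functional assay on RPMI-8226 cells (Homo sapiens) for cytotoxicity, read by sulforhodamine B assay, with a stated time of 48 h; on this read-out higher numbers stand for weaker inhibition of growth and lower numbers for stronger inhibition of growth. Compound 1 gives 9340 nM. Compound 2 gives 1540 nM, the lower of the two numbers; the gap between compound 2 and compound 1 lies beyond the scatter of repeated measurements, so compound 2 stands as the stronger growth inhibitor of the pair.

The next compound is compound 3 `ClCc1ccccc1Cn1cnc2c(Cl)ncnc21`. It differs from compound 2 in one place: hydrogen in place of chloro on an aromatic carbon. Among the compounds with values here, no measured pair shows this same exchange, so its size cannot be read off from a step already known.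

For compound 3 the expectation is a modest shift toward a higher number in this assay than compound 2, because compound 2 with 1540 nM carries the chloro that compound 3 lacks; the shift is expected to be small, possibly within the scatter, and the step from a 2.3-fold higher number from compound 2 to compound 3 (0.36 log units; beyond the scatter) is an estimate only. Compound 3 is therefore expected at about 3500 nM, with a likely range from 1400 nM to 9000 nM.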

Compound 3, concentration for total growth inhibition: 40700 nM
The estimate for compound 3 lay 12-fold (1.07 log units) below the measured number; measured number above the stated range.
By their numbers in this assay, from the lowest: compound 2; then compound 1; then compound 3.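

In this assay the chloro on the aromatic carbon between two ring nitrogen atoms proves to matter: its exchange for hydrogen gives a 26-fold higher number from compound 2 to compound 3 (1.42 log units; beyond the scatter) and is a large step. Within the data shown here, this is the first single-place change that can be read, and it shows that this position is not a silent one on this read-out, with compound 2, which keeps the chloro, as the stronger growth inhibitor of the pair. Nothing at hand bears on what lies behind the size of this step.

The compounds shown carry only chloro or hydrogen at this position, so it stays open whether an amine, a methoxy group or a fluoro group there would stay close to compound 2 or fall toward compound 3. Among these compounds, it also stays open whether the same exchange gives a step of similar size with the chloromethyl group placed as in compound 1, as this series so far offers a single reading of the change.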